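From Carboxy to Methoxycarbonyl: What to Expect

The source may report more compounds than this note shows. Statements on the series, on what has been measured and on what is new or still open speak of the compounds shown alone.

Measured so far:
compound 1, `CC#CCn1c(N2CCC[C@@H](N)C2)nc2c1c(=O)n(Cc1ccccc1C(=O)O)c(=O)n2C`: > 100000 nM
compound 2, `CC#CCn1c(N2CCC[C@@H](N)C2)nc2c1c(=O)n(Cc1cc(C#N)ccc1C(=O)O)c(=O)n2C`: > 100000 nM

Two compounds share one core and differ in a single spot. Compound 1, `CC#CCn1c(N2CCC[C@@H](N)C2)nc2c1c(=O)n(Cc1ccccc1C(=O)O)c(=O)n2C`, was tested in an ADME assay on isolated protein for inhibition of Dipeptidyl peptidase 9 (Homo sapiens), with stated times of 15 min, 60 s and 20 min (a lower number here means a stronger inhibitor, a higher number a weaker inhibitor), and gives > 100000 nM, which is a limit of the assay rather than a number. Compound 2, `CC#CCn1c(N2CCC[C@@H](N)C2)nc2c1c(=O)n(Cc1cc(C#N)ccc1C(=O)O)c(=O)n2C`, carries a cyano in place of hydrogen on an aromatic carbon and gives > 100000 nM, also a limit. The step that the two limits leave unreadable from compound 1 to compound 2 therefore cannot be read. Compound 1 thus stands only at the limit of > 100000 nM in this assay, at which 2 of the 2 values shown sit, with no number of its own.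

Compound 3, `CC#CCn1c(N2CCC[C@@H](N)C2)nc2c1c(=O)n(Cc1ccccc1C(=O)OC)c(=O)n2C`, differs from compound 1 by methyl in place of hydrogen on an oxygen next to a carbonyl group. For the measured compounds named here, no measured step bears on this change, since both known values are limits. Compound 3 is therefore expected to remain near that limit, a step of a number no higher from compound 1 to compound 3 (the limit leaves the size open) of no readable size, and its estimated value is 100000 nM, within 20000 nM to 300000 nM.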

Compound 3, half-maximal inhibitory concentration: > 100000 nM
Compound 3: no number, only a limit (the forecaster's own chance of this, stated with the estimate: 70%); the middle value sits exactly at the limit.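

In this assay compound 3 gives > 100000 nM as a limit of the assay, not a number. For the compounds shown here, compound 1 and compound 2 also stand at a limit, so no step among the three can be read. On these data alone, how strongly any of them inhibits remains open.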